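Removing the chloro group from compound 1

A few compounds are considered here, and "the series" means these few. Any claim that something is new, unique, unknown or untested is made for them only; others in the source may bear on it.

Of the compounds shown here, two have numbers so far. Compound 1 `Nc1ccnc(SCc2ccc(Cl)cc2)n1` was tested in an assay on isolated protein for inhibition of deoxycytidine kinase (Rattus norvegicus) (on this read-out higher numbers stand for weaker inhibition and lower numbers for stronger inhibition), and compound 1 gives 1000000 nM. Compound 2 `CCCCCSc1nccc(N)n1` is the other measured member; in this assay compound 2 gives 2600000 nM. Going by the values given here, on these two numbers compound 1 stands lowest, and its only neighbour, compound 2, sits a step higher that lies beyond the scatter. Among the compounds with values here, no pair among the measured compounds differs in a single place, so no measured single-site step is available to lean on.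

Compound 3 `Nc1ccnc(SCc2ccccc2)n1` is the next member to be measured. It differs from compound 1 by hydrogen in place of chloro on an aromatic carbon. With no measured step of this kind in the series, the expectation rests on the two numbers alone: the change strips one heavy atom from compound 1 and nothing else, so the number is expected to move toward weaker inhibition by a modest step, a 2.0-fold higher number from compound 1 to compound 3 (0.30 log units; within the scatter), a step that may or may not clear the scatter. Compound 3 is therefore estimated at 2000000 nM in this assay, with a range from 800000 nM to 6000000 nM.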

Compound 3, half-maximal inhibitory concentration: 2800000 nM
Compound 3: middle estimate off by 1.4-fold (0.15 log units), on the low side, within the range that was stated.
By their numbers in this assay, from the lowest: compound 1; then compounds 2 and 3 (each within the scatter of the next).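

In this assay the series now has its first measured single-site step: hydrogen in place of chloro, on an aromatic carbon of a six-membered aromatic ring of carbon only and para to a group of 9 heavy atoms, gives a 2.8-fold higher number from compound 1 to compound 3 (0.45 log units; beyond the scatter). The step is modest but clears the scatter, so the chloro group at this place goes with stronger inhibition than hydrogen, which the two earlier numbers could not show, as those compounds differ in more than one place. Nothing measured on these compounds accounts for the step, so its origin stays unassigned.

Going by these compounds, this remains a single comparison at a single place, so it is open whether the step belongs to chloro itself or whether a fluoro, bromo, methyl or methoxy group at the same carbon would shift the number in the same way. Also open, on these data alone, is how a chloro group would read on other carbons of that ring, and how an amine or a carboxylic acid would read at this place.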